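Swapping Pyridin-4-yl for 5-Nitrofuran-2-yl at the Carbonyl

The source may hold more compounds than are shown below. What is called first, only, known or untested is meant among the compounds shown, and "the series" means these compounds.

Three compounds built on one shared core have been examined in a functional assay on MCF7 cells (Homo sapiens) for antiproliferative activity, read by MTT assay, with a stated time of 72 h; on this read-out lower numbers stand for stronger inhibition and higher numbers for weaker inhibition. Compound 1 `CC(=O)O[C@H]1CC[C@]2(C)[C@H](CC[C@@](C)(O)[C@H]2CC[C@@H]2C(C)=CC[C@H]3[C@H](CC[C@]3(C)OC(C)=O)C2(C)C)OC1(C)C` gives 39200 nM. Compound 2 `CC1=CC[C@H]2[C@H](CC[C@]2(C)O)C(C)(C)[C@@H]1CC[C@H]1[C@]2(C)CC[C@H](OC(=O)c3ccncc3)C(C)(C)O[C@H]2CC[C@@]1(C)O` gives 25300 nM, the lowest of the two numbers reported, though compound 1 sits within the scatter of it and no order can be read between the two. Compound 3 `CC1=CC[C@H]2[C@@H]1CC=C(C)[C@@H](CC[C@H]1[C@]3(C)CC[C@H](OCc4ccccc4)C(C)(C)O[C@H]3CC[C@@]1(C)O)C2(C)C` gives only a limit, > 50000 nM, in this assay. Of the three values, one is thus a limit rather than a number, namely (the limit of > 50000 nM in this assay, at which 1 of the 3 values shown sits).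

Compound 4 `CC1=CC[C@H]2[C@H](CC[C@]2(C)O)C(C)(C)[C@@H]1CC[C@H]1[C@]2(C)CC[C@H](OC(=O)c3ccc([N+](=O)[O-])o3)C(C)(C)O[C@H]2CC[C@@]1(C)O` has not yet been measured. It differs from compound 2 in one place: 5-nitrofuran-2-yl in place of pyridin-4-yl on a carbonyl carbon. Among the measured compounds shown here, no pair among the measured compounds shows this change, so its size cannot be read from the numbers at hand. In the absence of such a precedent, the step from compound 2 to compound 4 is expected to be a 1.2-fold lower number from compound 2 to compound 4 (0.06 log units; within the scatter), a move that is expected to stay within the scatter, with no confident direction. Compound 4 is therefore expected to give about 22000 nM in this assay, with a range from 8000 nM to 50000 nM.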

Compound 4, half-maximal inhibitory concentration: 21300 nM
Estimate against measurement, compound 4: 1.0-fold (0.01 log units) above, within the range that was stated.
By their numbers in this assay, from the lowest: compounds 4, 2 and 1 (each within the scatter of the next). At a limit, above all of these: compound 3.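

Among the compounds shown here, the exchange of pyridin-4-yl for 5-nitrofuran-2-yl on the carbonyl carbon gives, in this assay, a 1.2-fold lower number from compound 2 to compound 4 (0.07 log units; within the scatter), and this is the first step at this position whose size can be read. The entering group is a five-membered aromatic ring with more heavy atoms and more hydrogen-bond acceptors than the six-membered aromatic ring that leaves, yet the two compounds cannot be told apart on this read-out, so this position accepts both aromatic groups with no measurable difference. The numbers shown offer no measured property that could explain this closeness.

From the compounds shown here alone, both groups compared here are aromatic rings on the same carbonyl carbon, so it remains open whether a plain phenyl ring would also stay within the scatter, or whether a group of another kind, such as an amine or a carboxylic acid carried on a longer chain, would stand clearly apart from them. Going by these compounds, it also remains open whether the same exchange on the carbonyl carbon would give so small a step on any other cell line.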